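Swapping dipropylamino for (4-methylphenyl)amino on the shared core

The source may hold more compounds than are shown below. What is called first, only, known or untested is meant among the compounds shown, and "the series" means these compounds.

Measured in a functional assay on MCF7 cells (Homo sapiens) for inhibition, read by sulforhodamine B assay (on this read-out lower numbers stand for stronger inhibition and higher numbers for weaker inhibition), so far:
- compound 1 `CCCc1ccc(NC2=CC(=O)c3nc4n(c3C2=O)[C@H]2OC[C@@H](O)[C@H]2OC4)cc1` gives 4660 nM as a number
- compound 2 `CCCN(CCC)C1=CC(=O)c2nc3n(c2C1=O)[C@H]1OC[C@@H](O)[C@H]1OC3` gives > 16000 nM as a limit

Compound 2 stands at the limit of > 16000 nM in this assay, at which 1 of the 2 values shown sits, and this is a limit, not a number. Compound 3 `Cc1ccc(NC2=CC(=O)c3nc4n(c3C2=O)[C@H]2OC[C@@H](O)[C@H]2OC4)cc1` differs from it by (4-methylphenyl)amino in place of dipropylamino on a double-bonded ring carbon with (4-methylphenyl)amino in place of dipropylamino on a double-bonded ring carbon. Compound 1 also has an aromatic ring in that group and gives 4660 nM as a real number. The expected at least 2.6-fold lower number from compound 2 to compound 3 (0.42 log units; beyond the scatter) would mean stronger inhibition in this assay beyond the usual scatter. Compound 3 is estimated at 6000 nM within an expected range of 2500 nM to 14000 nM in this read-out.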

Compound 3, half-maximal inhibitory concentration: 1660 nM
Beside the measured number, compound 3's estimate is 3.6-fold (0.56 log units) above it, outside the stated range (below it).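

In this assay, (4-methylphenyl)amino in place of dipropylamino on a double-bonded ring carbon gives an at least 9.6-fold lower number from compound 2 to compound 3 (0.98 log units; beyond the scatter), so the group at this position clearly matters. From the compounds shown here alone, the true size of that step stays open, as compound 2 has a limit and not a number: the limit of > 16000 nM in this assay, at which 1 of the 3 values shown sits. The end of the aromatic group counts too, with hydrogen in place of ethyl on a saturated chain carbon bound to an aromatic carbon giving a 2.8-fold lower number from compound 1 to compound 3 (0.45 log units; beyond the scatter).

The compounds shown leave open whether the aromatic ring or the amino hydrogen accounts for the first step. A cyclohexylamino group, or a methoxy group on the aromatic ring, could help separate these.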